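A few compounds are considered here, and "the series" means these few. Any claim that something is new, unique, unknown or untested is made for them only; others in the source may bear on it.

Of the compounds shown here, three sharing one core have been measured in an assay on blood for inhibition of Polyunsaturated fatty acid 5-lipoxygenase (Homo sapiens); on this read-out higher numbers stand for weaker inhibition and lower numbers for stronger inhibition. Compound 1 `CC(=O)C1(c2cc(F)cc(OCc3ccc(-n4ccnc4C)cc3)c2)CCOCC1` carries an acetyl group on a saturated ring carbon and gives 130 nM. Compound 2 `CCOC1(c2cc(F)cc(OCc3ccc(-n4ccnc4C)cc3)c2)CCOCC1` carries an ethoxy group in the same place and gives 80 nM; the step of a 1.6-fold lower number from compound 1 to compound 2 (0.21 log units; within the scatter) is small. Compound 3 `Cc1nccn1-c1ccc(COc2cc(F)cc(C3(S(C)(=O)=O)CCOCC3)c2)cc1` carries a methylsulfonyl group there. For compound 3 this assay reports only a limit, > 1000 nM, not a number, so compound 3 stands at the limit of > 1000 nM in this assay, at which 1 of the 3 values shown sits, and is the only one of the three without a measured value.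

Compound 4 `CCOC(=O)C1(c2cc(F)cc(OCc3ccc(-n4ccnc4C)cc3)c2)CCOCC1` is not yet measured. It differs from compound 3 by ethoxycarbonyl in place of methylsulfonyl on a saturated ring carbon. Going by the values given here, two measured steps bear on this change: an at least 7.6-fold higher number from compound 1 to compound 3 (0.88 log units; beyond the scatter) and an at least 12-fold higher number from compound 2 to compound 3 (1.09 log units; beyond the scatter), both beyond the scatter and both leading from a numbered value to the limit. Replacing the methylsulfonyl group by an ethoxycarbonyl group, which carries a carbonyl as the acetyl of compound 1 does, is therefore expected to reverse that loss, giving a step of an at least 6.2-fold lower number from compound 3 to compound 4 (0.79 log units; beyond the scatter). For compound 4 the expected value in this assay is 160 nM, with a range from 50 nM to 600 nM.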

Compound 4, half-maximal inhibitory concentration: 200 nM
Estimate against measurement, compound 4: 1.3-fold (0.10 log units) below; low and high end bracket the measured number.
By their numbers in this assay, from the lowest: compounds 2, 1 and 4 (each within the scatter of the next, the first and the last beyond it). At a limit, above all of these: compound 3.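

In this assay, going by these compounds alone, compound 3 remains the only compound held at a limit and not a number: the limit of > 1000 nM in this assay, at which 1 of the 4 values shown sits. Within the data shown here, exchanging its group on the saturated ring carbon gives an at least 5.0-fold lower number from compound 3 to compound 4 (0.69 log units; beyond the scatter) and, since methylsulfonyl and ethoxycarbonyl show the same count of hydrogen-bond acceptors and neither has a donor, that count does not separate the group at the limit from the one with a measured number. Among the measured compounds, the change of ethoxy in place of methyl on a carbonyl carbon gives a 1.5-fold higher number from compound 1 to compound 4 (0.19 log units; within the scatter) and so does not clearly move the number, while ethoxycarbonyl in place of ethoxy gives a 2.5-fold higher number from compound 2 to compound 4 (0.40 log units; beyond the scatter) and so does move it, if only modestly.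

As far as these compounds go, the true number for compound 3 remains unknown, so the full size of the step from it cannot be read. The compounds shown also leave open how a carboxylic acid, an amide or an ester with a longer chain would fare at this position, and whether an ethylsulfonyl group would behave like methylsulfonyl.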